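Swapping the 4-chlorophenyl group of compound 3

The source may hold more compounds than are shown below. What is called first, only, known or untested is meant among the compounds shown, and "the series" means these compounds.

Measured in a functional assay on NCI-H460 cells (Homo sapiens) for antiproliferative activity, read by MTT assay, with a stated time of 48 h; a higher number here means a weaker inhibitor, a lower number a stronger inhibitor:
compound 1 `COc1cc(-c2cccc3nc(-c4ccccc4)oc23)cc(OC)c1OC`: 6800 nM
compound 2 `COc1cc(-c2cccc3nc(-c4cccc(F)c4)oc23)cc(OC)c1OC`: 3300 nM
compound 3 `COc1cc(-c2cccc3nc(-c4ccc(Cl)cc4)oc23)cc(OC)c1OC`: > 25000 nM (a limit, not a number)

Compound 3 stands at > 25000 nM, and that is a limit of the assay. For the measured compounds named here, it is the only one of the three compounds without an actual number.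

Compound 4 `COc1cc(-c2nc3cccc(-c4cc(OC)c(OC)c(OC)c4)c3o2)ccc1O` has not yet been measured. It keeps the core of compound 3 and changes one group, with 4-hydroxy-3-methoxyphenyl in place of 4-chlorophenyl on an aromatic carbon. The three measured compounds differ in the group at this same place, so their steps are the best guide available.

Arriving at compound 3 raised the number both times, in an at least 3.6-fold higher number from compound 1 to compound 3 (0.56 log units; beyond the scatter) and in an at least 7.5-fold higher number from compound 2 to compound 3 (0.87 log units; beyond the scatter). Those steps are at least modest. The step between the other two is smaller, at a 2.1-fold lower number from compound 1 to compound 2 (0.31 log units; beyond the scatter). Leaving the 4-chlorophenyl group is therefore expected to lower the number in this assay by at least a modest step, back towards compound 1 and compound 2. Going by the values given here, no measured compound carries the entering group, which keeps the range wide.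

The estimated step is an at least 5.0-fold lower number from compound 3 to compound 4 (0.69 log units; beyond the scatter). For compound 4 the expected value is 5000 nM, with an estimated range from 1200 nM to 20000 nM.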

Compound 4, half-maximal inhibitory concentration: 2000 nM
Estimate against measurement, compound 4: 2.5-fold (0.40 log units) above, and the stated range covers the measured number.
By their numbers in this assay, from the lowest: compounds 4 and 2 (each within the scatter of the next); then compound 1. At a limit, above all of these: compound 3.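

In this assay, putting 4-hydroxy-3-methoxyphenyl in place of 4-chlorophenyl gives an at least 12-fold lower number from compound 3 to compound 4 (1.09 log units; beyond the scatter), so a substituted phenyl ring with more heavy atoms, carrying a hydrogen-bond donor and acceptors, can sit at this position without the loss seen with compound 3. Against the plain phenyl group there is a 3.4-fold lower number from compound 1 to compound 4 (0.53 log units; beyond the scatter), which shows that a ring with two substituents can do better here than a ring with none, while a 1.7-fold lower number from compound 2 to compound 4 (0.22 log units; within the scatter) leaves compound 4 and compound 2 indistinguishable in this assay, despite their different substituents. The largest of these steps has a true number at only one end, as compound 3 carries a limit and not a number: the limit of > 25000 nM in this assay, at which 1 of the 4 values shown sits.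

The compounds shown leave open whether the hydroxy or the methoxy group of compound 4 matters more, as neither stands alone on the ring here. Also open, from the compounds shown here alone, is how an amine or a carboxylic acid in place of the hydroxy group would read in this assay.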